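The source may hold more compounds than are shown below. What is called first, only, known or untested is meant among the compounds shown, and "the series" means these compounds.

In an ADME assay on MT4 cells (Homo sapiens) for cytotoxicity, read by MTT assay, with a stated time of 4 days (a higher number here means that more compound is tolerated, a lower number that less compound is tolerated), compound 1 `CC(C)N(C)c1nc(Cc2c(F)cccc2F)cc(=O)[nH]1` gives 85000 nM as a measured number. Compound 2 `CCCN(CCC)c1nc(Cc2c(F)cccc2F)cc(=O)[nH]1` shows > 78000 nM there, which is a limit only. Compound 3 `O=c1cc(Cc2c(F)cccc2N2CCCC2)nc(N2CCCC2)[nH]1` shows > 73000 nM there, also a limit. Compound 2 therefore has no readable number to start from. Compound 4 `CN1CCN(c2nc(Cc3c(F)cccc3F)cc(=O)[nH]2)CC1` differs from compound 2 by one change on an aromatic carbon between two ring nitrogen atoms: 4-methylpiperazin-1-yl in place of dipropylamino on an aromatic carbon is the whole of it. For the measured compounds named here, the only measured step at this place is a step that the limit leaves unreadable from compound 1 to compound 2 and its size cannot be read. In this assay the expected step of an at least 1.0-fold lower number from compound 2 to compound 4 (0.01 log units; that floor lies within the scatter) is thus estimated to stay within the scatter, with no direction foreseen. Compound 4 is estimated at 75000 nM with 35000 nM and 120000 nM as the expected ends of its range.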

Compound 4, half-maximal cytotoxic concentration: > 78000 nM
Compound 4 gave a limit, no number; the forecaster's own chance of this, stated with the estimate: 65%; middle value at least 1.0-fold (0.01 log units) away from the limit.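

In this assay compound 4 gives > 78000 nM, a limit and not a number, so its steps from compound 1 and compound 2 cannot be read. The compounds shown leave open whether 4-methylpiperazin-1-yl and dipropylamino differ here at all.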